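This account rests on a few compounds, and the source may have more. Where it says the series, first, only, none or still open, it means among the compounds named here.

Compound 1 `C=CCc1cc(C(C)=O)c(O)cc1OCCCCCCCCC#N` gives 86% in an assay on isolated protein for inhibition of leukotriene B4 receptor 1 (Homo sapiens), tested at 10 uM; a lower number here means less inhibition, a higher number more inhibition at the concentration tested (going by the name of the read-out); compound 2 `CCc1cc(C(C)=O)c(O)cc1OCCCC(C)(C)C(=O)O` gives 89% in the same assay.

Both measured compounds share a core and differ in more than one place, so no single step can be read between them; their two values lie within the scatter of each other, and no order between compound 1 and compound 2 can be drawn from these numbers. Among the measured compounds shown here, compound 1 thus stands level with the only other measured compound on this read-out.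

Compound 3 `C=CCc1cc(C(C)=O)c(O)cc1OCCCCCC(=O)N(C)C` has not yet been measured in this assay. It differs from compound 1 in one place: dimethylcarbamoyl in place of 3-cyanopropyl on a saturated chain carbon, five bonds along the chain from an oxygen on an aromatic ring. For the measured compounds named here, no measured pair shows what this kind of change does to the read-out, so the expectation for compound 3 rests on compound 1 alone. With compound 1 at 86% and compound 2 at a value within the scatter of it, compound 3 is expected to give a number in this assay close to both, with an expected step of a number 6 percentage points lower from compound 1 to compound 3 (within the scatter), which is not beyond the scatter. The estimate for compound 3 is 80%, with a range from 60% to 95%.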

Compound 3, a percentage reported as inhibition, at one concentration (the size of the read-out at that concentration, not a potency): 92%
For compound 3 the middle estimate is 12 percentage points below the measured one; the measured number falls inside the stated range.
By their numbers in this assay, from the lowest: compounds 1, 2 and 3 (each within the scatter of the next).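

Among the compounds shown here, the change from 3-cyanopropyl to dimethylcarbamoyl, on a saturated chain carbon, five bonds along the chain from an oxygen on an aromatic ring, gives the first step that can be read in this assay, and that step is a number 6 percentage points higher from compound 1 to compound 3 (within the scatter). At this place, then, a chain ending in a nitrile and a chain ending in a dimethyl amide cannot be told apart on this read-out, although the two groups have the same count of heavy atoms and differ in their atoms and in the kind of multiple bond they carry. Nothing available explains why the two groups read alike.

What the compounds shown leave open is whether an amine or a hydroxyl group at this same place would stay level with compound 1 or give a number clearly apart from it, since this one step does not show how much the read-out depends on the group here. From the compounds shown here alone, because the read-out comes from a single concentration, it also remains open whether compound 1 and compound 3 would separate in a full measurement of potency.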